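The compounds below may be only part of what the source reports. "The series", "measured", "known", "first", "only" and "open" are said of these compounds alone.

Of the compounds shown here, three built on one shared core have been measured in an assay on isolated protein for inhibition of histamine H2 receptor (Cavia porcellus); a higher number here means weaker binding, a lower number tighter binding. Compound 1 `COc1ccc(N/C(S)=N/CCCOc2cccc(CN3CCCCC3)c2)cc1` gives 4370 nM. Compound 2 `O=C(NCCCOc1cccc(CN2CCCCC2)c1)Nc1cccc(C(F)(F)F)c1` gives 813 nM. Compound 3 `COc1ccc(NC(=O)NCCCOc2cccc(CN3CCCCC3)c2)c(OC)c1` gives 2240 nM. Of these three numbers, compound 3 holds the second highest; compound 1 lies closest to it, within the scatter, while compound 2 lies farther off, beyond the scatter. For the measured compounds named here, the one step between measured compounds that differ in a single place is a 2.8-fold higher number from compound 2 to compound 3 (0.44 log units; beyond the scatter), a modest change that came from exchanging one aromatic ring for another on the amide-type nitrogen.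

Compound 4 `CNC(=O)NCCCOc1cccc(CN2CCCCC2)c1` has not yet been measured. It differs from compound 3 in one place: methyl in place of 2,4-dimethoxyphenyl on an amide-type nitrogen. Going by the values given here, no measured pair shows what removing the aromatic ring from this nitrogen altogether does. Among the compounds with values here, the only step on that nitrogen swapped one ring for another and shifted the number modestly. Taking the ring away entirely is a larger change, so a shift beyond the scatter is plausible, and weaker binding seems the more likely outcome, though the direction is not settled by the data. The number for compound 4 is therefore expected to fall near 5000 nM, within a range from 1200 nM to 20000 nM. That estimate corresponds to an expected step of a 2.2-fold higher number from compound 3 to compound 4 (0.35 log units; beyond the scatter) in this assay.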

Compound 4, dissociation constant: 155 nM
The estimate for compound 4 lay 32-fold (1.51 log units) above the measured number, outside the stated range (below it).
By their numbers in this assay, from the lowest: compound 4; then compound 2; then compounds 3 and 1 (each within the scatter of the next).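

On this amide-type nitrogen, the earlier exchange of one aromatic ring for another moved the number only modestly, while removing the ring has a much larger effect. In this assay, methyl in place of 2,4-dimethoxyphenyl gives a 14-fold lower number from compound 3 to compound 4 (1.16 log units; beyond the scatter) and methyl in place of 3-(trifluoromethyl)phenyl gives a 5.2-fold lower number from compound 2 to compound 4 (0.72 log units; beyond the scatter), so the change tightens binding from both starting points, and an aromatic ring on this nitrogen is clearly not needed for binding to this receptor. No measurement offered here explains why losing the ring tightens binding.

The compounds shown contain only two aromatic groups and one methyl at this position, so it remains open how the number changes across the range between them, for example with an ethyl group, a longer alkyl chain or a cyclohexyl ring. It is also unknown whether replacing methyl with a bare hydrogen would tighten binding further or weaken it.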